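This account rests on a few compounds, and the source may have more. Where it says the series, first, only, none or still open, it means among the compounds named here.

Measured so far in the series:
- Compound 1, `CN(C)C(=O)c1cc2cnc(Nc3ccc(NC(=O)C4(C(=O)Nc5ccccc5F)CC4)cc3)nc2n1C1CCCC1`: in a functional assay on OVCAR-5 cells (Homo sapiens) for inhibition, read by CCK-8 assay, with a stated time of 72 h, tested at 1 uM (a lower number here means less inhibition of growth, a higher number more inhibition of growth at the concentration tested), compound 1 gives 58%.
- Compound 2, `CN(C)C(=O)c1cc2cnc(Nc3ccc(NC(=O)C4(C(=O)Nc5cccc(O)c5)CC4)cc3)nc2n1C1CCCC1`: in this assay compound 2 gives 58.5%.
- Compound 3, `CN(C)C(=O)c1cc2cnc(Nc3ccc(NC(=O)C4(C(=O)Nc5ccc(F)cc5)CC4)cc3F)nc2n1C1CCCC1`: in this assay compound 3 gives -0.9%.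

Compound 2 holds the largest of the three numbers in this assay, but compound 1 lies within the scatter of it, so the two cannot be ordered. For the measured compounds named here, compound 3 sits far lower; it differs from compound 1 in two places and from compound 2 in more than one, so no single step connects it to either, and the values only show a wide gap.

Compound 4, `CN(C)C(=O)c1cc2cnc(Nc3ccc(NC(=O)C4(C(=O)Nc5ccc(Cl)c(C(F)(F)F)c5)CC4)cc3)nc2n1C1CCCC1`, is not yet measured. It differs from compound 2 in one place: 4-chloro-3-(trifluoromethyl)phenyl in place of 3-hydroxyphenyl on an amide-type nitrogen. Going by the values given here, the one measured step at this position, a number 0.5 percentage points higher from compound 1 to compound 2 (within the scatter), stayed within the scatter when the group on the amide-type nitrogen was exchanged. Among the compounds with values here, no measured step covers the group that enters here, so the expectation rests on that single exchange alone. A step within the scatter in this assay, in either direction, is therefore expected. The estimate for compound 4 is 55%, with a range of 35% to 75%. That corresponds to an expected step of a number 3.5 percentage points lower from compound 2 to compound 4 (within the scatter).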

Compound 4, percent growth inhibition at one concentration: -2.4%
Compound 4: the middle estimate sits 57.4 percentage points above what was measured; the whole stated range lies above it.
By their numbers in this assay, from the lowest: compounds 4 and 3 (each within the scatter of the next); then compounds 1 and 2 (each within the scatter of the next).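

In this assay the position on the amide-type nitrogen proves sensitive to the group placed there, which the first exchange did not reveal. The change to 4-chloro-3-(trifluoromethyl)phenyl gives a number 60.9 percentage points lower from compound 2 to compound 4 (beyond the scatter) when it replaces 3-hydroxyphenyl and a number 60.4 percentage points lower from compound 1 to compound 4 (beyond the scatter) when it replaces 2-fluorophenyl, so the large loss of growth inhibition at the tested concentration appears from both starting groups. The earlier reading of a number 0.5 percentage points higher from compound 1 to compound 2 (within the scatter) therefore speaks for those two groups only and not for the position as a whole.

Because the chloro and trifluoromethyl substituents enter together, the compounds shown do not separate their contributions, and they leave open whether a phenyl ring carrying a carboxylic acid or an aminomethyl group on this nitrogen would stay with compound 1 and compound 2 or fall with compound 4. No available measurement bears on what lies behind the drop.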